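A few compounds are considered here, and "the series" means these few. Any claim that something is new, unique, unknown or untested is made for them only; others in the source may bear on it.

Measured so far in a functional assay on PANC-1 cells (Homo sapiens) for inhibition, read by MTT assay, with a stated time of 24 h, tested at 10 uM; a lower number here means less inhibition, a higher number more inhibition at the concentration tested (going by the name of the read-out):

Compound 1, `CC(C)=CCC/C(C)=C/COc1cc(=O)n(CCCO)c2c1CC(CC=C(C)C)C(C)(C)C2`: 10.6%
Compound 2, `COc1ccc(NC(=O)Oc2cc(=O)n(CCCO)c3c2CC(CC=C(C)C)C(C)(C)C3)cc1`: 3.7%

Compound 2 stands lowest of the two numbers recorded in this assay, and its nearest neighbour is compound 1, which sits higher by an amount that stays within the scatter: a number 6.9 percentage points lower from compound 1 to compound 2 (within the scatter). The two compounds are therefore not separable on these figures.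

Compound 3, `COc1cccc(NC(=O)Oc2cc(=O)n(CCCO)c3c2CC(CC=C(C)C)C(C)(C)C3)c1`, is not yet measured. It is built from compound 2 with the same atoms joined differently, as follows: 3-methoxyphenyl in place of 4-methoxyphenyl on an amide-type nitrogen.

Among the compounds with values here, only one measured step exists, a number 6.9 percentage points lower from compound 1 to compound 2 (within the scatter), and it concerns a different part of the molecule, the group on the oxygen on the aromatic ring of the shared core, where (4-methoxyphenyl)carbamoyl replaced 3,7-dimethylocta-2,6-dien-1-yl. Within the data shown here, no measured step exchanges 4-methoxyphenyl for 3-methoxyphenyl on the amide-type nitrogen, so nothing in the data points in either direction. Among the measured compounds shown here, the one step known was within the scatter, and the expected step from compound 2 to compound 3 is likewise none beyond the scatter: a number 1.3 percentage points higher from compound 2 to compound 3 (within the scatter). For compound 3 the estimated value in this assay is 5%, with an expected range from -5% to 16%.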

Compound 3, a percentage reported as inhibition, at one concentration (the size of the read-out at that concentration, not a potency): 16.2%
Estimate against measurement, compound 3: 11.2 percentage points below; the measured number lies above the stated range.
By their numbers in this assay, from the lowest: compounds 2, 1 and 3 (each within the scatter of the next, the first and the last beyond it).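

Among the three compounds in this assay, only the exchange of 4-methoxyphenyl for 3-methoxyphenyl on the amide-type nitrogen gives a step beyond the scatter, a number 12.5 percentage points higher from compound 2 to compound 3 (beyond the scatter), and it does so with the same atoms joined differently. This shows that the figures at this position can respond to where the methoxy group is attached to the phenyl ring, although the step is modest. By contrast, (3-methoxyphenyl)carbamoyl in place of 3,7-dimethylocta-2,6-dien-1-yl on the oxygen gives a number 5.6 percentage points higher from compound 1 to compound 3 (within the scatter), so that exchange is no more separable with the 3-methoxyphenyl group than it was with the 4-methoxyphenyl group; no evidence accounts for the step at the amide-type nitrogen.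

The compounds shown leave open whether the step depends on the methoxy group itself, a question that an unsubstituted phenyl, a 2-methoxyphenyl, or a 3-hydroxyphenyl or 3-aminophenyl group on the same nitrogen could address. They also leave open whether the difference would persist beyond a single concentration, since compound 3, at 16.2%, is described here only by a percentage and not by a potency.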